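A few compounds are considered here, and "the series" means these few. Any claim that something is new, unique, unknown or untested is made for them only; others in the source may bear on it.

Measured so far:
- compound 1 `CN(C)C(=O)c1cc2cnc(Nc3ccc(NC(=O)C4(C(=O)Nc5ccccc5F)CC4)cc3)nc2n1C1CCCC1`: 28.2%
- compound 2 `CN(C)C(=O)c1cc2cnc(Nc3ccc(NC(=O)C4(C(=O)Nc5ccc(Br)cc5)CC4)cc3)nc2n1C1CCCC1`: 31.5%
- compound 3 `CN(C)C(=O)c1cc2cnc(Nc3ccc(NC(=O)C4(C(=O)Nc5cccc(F)c5)CC4)cc3)nc2n1C1CCCC1`: 45.1%

In a functional assay on NCI-H460 cells (Homo sapiens) for inhibition, read by CCK-8 assay, with a stated time of 72 h, tested at 1 uM (a higher number here means more inhibition of growth at the concentration tested, a lower number less inhibition of growth), compound 3 gives 45.1%, the highest of the three numbers; its separation from compound 2 is a number 13.6 percentage points higher from compound 2 to compound 3 (beyond the scatter), and from compound 1 it is a number 16.9 percentage points higher from compound 1 to compound 3 (beyond the scatter), both beyond the scatter. Compound 1 and compound 2 lie within the scatter of each other, a number 3.3 percentage points higher from compound 1 to compound 2 (within the scatter).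

Compound 4 `CN(C)C(=O)c1cc2cnc(Nc3ccc(NC(=O)C4(C(=O)Nc5ccc(F)cc5)CC4)cc3)nc2n1C1CCCC1` has the same atoms as compound 3, joined differently: 4-fluorophenyl in place of 3-fluorophenyl on an amide-type nitrogen.

Within the data shown here, the steps that bear on this are the two that end at compound 3. Both replacements of the aryl group on that amide-type nitrogen, from 2-fluorophenyl and from 4-bromophenyl, gave modest gains on reaching 3-fluorophenyl, a number 16.9 percentage points higher from compound 1 to compound 3 (beyond the scatter) and a number 13.6 percentage points higher from compound 2 to compound 3 (beyond the scatter). Among the measured compounds shown here, no measured compound carries 4-fluorophenyl at this site, so the new group is not directly covered. The nearest neighbour is the 4-bromophenyl analogue, compound 2, which sits below compound 3; a move away from 3-fluorophenyl is therefore expected to cost rather than gain, by a modest amount, a number 10.1 percentage points lower from compound 3 to compound 4 (beyond the scatter).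

Compound 4 is estimated at 35% in this assay, in a range from 22% to 48%.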

Compound 4, percent growth inhibition at one concentration: 79.9%
Estimate against measurement, compound 4: 44.9 percentage points below; the measured number lies above the stated range.
By their numbers in this assay, from the lowest: compounds 1 and 2 (each within the scatter of the next); then compound 3; then compound 4.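

In this assay, the aryl group on the amide-type nitrogen proves far more sensitive than the first three compounds suggested: with the same atoms, 4-fluorophenyl in place of 3-fluorophenyl gives a large gain (a number 34.8 percentage points higher from compound 3 to compound 4 (beyond the scatter)), and 4-fluorophenyl in place of 2-fluorophenyl gives a still larger one (a number 51.7 percentage points higher from compound 1 to compound 4 (beyond the scatter)). Substitution at the same ring carbon does not by itself account for the gain, since compound 2 and compound 4 differ only in the halogen, and fluoro in place of bromo also gives a large step (a number 48.4 percentage points higher from compound 2 to compound 4 (beyond the scatter)). The three fluorophenyl isomers therefore separate clearly, in the order compound 1, compound 3, compound 4, but nothing available explains either the isomer order or the halogen effect.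

From the compounds shown here alone, it remains open whether the high value belongs to fluoro specifically or extends to other groups at this site, such as 4-chlorophenyl, 4-methylphenyl, 4-methoxyphenyl or unsubstituted phenyl. A second fluoro on the ring, as in 2,4-difluorophenyl or 3,4-difluorophenyl, is also untested ground in the compounds shown, so it cannot be said whether the steps seen here would add together.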